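Swapping the Aryl Ring on a Urea-Linked Hydrazone

The compounds below may be only part of what the source reports. "The series", "measured", "known", "first", "only" and "open" are said of these compounds alone.

Compound 1 `CN(C)CCn1cnnc1-c1cc(Oc2ccc(NC(=O)N/N=C/c3c(Cl)cccc3Cl)cc2F)ccn1` gives 1410 nM in a functional assay on A549 cells (Homo sapiens) for cytotoxicity, read by MTT assay, with a stated time of 72 h; a higher number here means a weaker inhibitor, a lower number a stronger inhibitor. Compound 2 `CN(C)CCn1cnnc1-c1cc(Oc2ccc(NC(=O)N/N=C/c3ccc(F)cc3)cc2F)ccn1` gives 1790 nM in this assay. Compound 3 `CN(C)CCn1cnnc1-c1cc(Oc2ccc(NC(=O)N/N=C/c3ccc(Cl)cc3)cc2F)ccn1` gives 780 nM in this assay.

Compound 3 has the lowest of the three numbers, though only its gap to compound 2 is beyond the scatter: a 2.3-fold lower number from compound 2 to compound 3 (0.36 log units; beyond the scatter). The other steps, a 1.8-fold lower number from compound 1 to compound 3 (0.26 log units; within the scatter) and a 1.3-fold higher number from compound 1 to compound 2 (0.10 log units; within the scatter), stay within the scatter. Compound 4 `COc1cc(/C=N/NC(=O)Nc2ccc(Oc3ccnc(-c4nncn4CCN(C)C)c3)c(F)c2)ccc1O` differs from compound 3 by 4-hydroxy-3-methoxyphenyl in place of 4-chlorophenyl on a carbon with a double bond to nitrogen. Among the compounds with values here, none of the measured steps tries a ring carrying a hydroxy or methoxy group, so they bear on this change only loosely, showing that changes on this ring have so far moved the number by modest amounts. For compound 4 a modest rise in this assay is expected, a 2.1-fold higher number from compound 3 to compound 4 (0.31 log units; beyond the scatter), giving an estimated 1600 nM with a range from 500 nM to 5000 nM.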

Compound 4, half-maximal inhibitory concentration: > 100000 nM
Compound 4 ended at the assay's limit (the forecaster's own chance of this, stated with the estimate: 10%); middle value at least 62-fold (1.79 log units) away from the limit.
By their numbers in this assay, from the lowest: compounds 3, 1 and 2 (each within the scatter of the next, the first and the last beyond it). At a limit, above all of these: compound 4.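

The ring on the carbon with a double bond to nitrogen proves far more sensitive than the halogenated rings suggested: 4-hydroxy-3-methoxyphenyl gives an at least 120-fold higher number from compound 3 to compound 4 (2.10 log units; beyond the scatter) and an at least 55-fold higher number from compound 2 to compound 4 (1.74 log units; beyond the scatter) and an at least 70-fold higher number from compound 1 to compound 4 (1.85 log units; beyond the scatter) against those rings. These steps are lower bounds, since the reading for compound 4 is a limit and not a number: the limit of > 100000 nM in this assay, at which 1 of the 4 values shown sits.

The compounds shown leave open whether the hydroxy group, the methoxy group or the two together go with this loss. Going by these compounds, how a ring carrying an amine or a carboxylic acid would behave also stays open.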